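The compounds below may be only part of what the source reports. "The series", "measured", "known", "first", "only" and "open" are said of these compounds alone.

Working notes on the series.

Three compounds share a core and have numbers in an assay on cells for antagonist activity at transient receptor potential cation channel subfamily V member 1 (Homo sapiens), read by FLIPR and calcium flux, with a stated time of 6 min; on this read-out lower numbers stand for stronger inhibition and higher numbers for weaker inhibition. Compound 1 `COCCCOc1nc(C(C)(C)C)ccc1CNC(=O)C(C)c1ccc(NS(C)(=O)=O)c(F)c1` gives 5.6 nM. Compound 2 `CC(C(=O)NCc1ccc(C(C)(C)C)nc1SCc1ccccc1Cl)c1ccc(NS(C)(=O)=O)c(F)c1` gives 3.8 nM; the step of a 1.5-fold lower number from compound 1 to compound 2 (0.17 log units; within the scatter) shows that swapping one ether-type chain for another on the same aromatic carbon leaves the read-out essentially where it was. Compound 3 `CC1CCN(c2cc(C(C)(C)C)ccc2CNC(=O)C(C)c2ccc(NS(C)(=O)=O)c(F)c2)CC1` gives 0.7 nM, the lowest of the three numbers, separated from compound 2 and from compound 1 by gaps that lie beyond the scatter.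

Compound 4 `CC(C)COc1cc(C(C)(C)C)ccc1CNC(=O)C(C)c1ccc(NS(C)(=O)=O)c(F)c1` is not yet measured. It differs from compound 3 in one place: isobutoxy in place of 4-methylpiperidin-1-yl on an aromatic carbon. Among the measured compounds shown here, no measured step covers this exchange of a ring-bearing amine substituent for an alkoxy chain; the only measured step, from compound 1 to compound 2, concerns two chains of that kind against each other and was within the scatter. The two compounds carrying a chain at this position, compound 1 and compound 2, both sit well above compound 3, so a move upward in this assay is expected for compound 4, with a 3.6-fold higher number from compound 3 to compound 4 (0.55 log units; beyond the scatter) as the working guess. For compound 4 the number in this assay is therefore estimated at 2.5 nM, between 0.8 nM and 8 nM.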

Compound 4, inhibition constant: 2.1 nM
Estimate against measurement, compound 4: 1.2-fold (0.08 log units) above; the range from low to high includes it.
By their numbers in this assay, from the lowest: compound 3; then compounds 4, 2 and 1 (each within the scatter of the next, the first and the last beyond it).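

In this assay, among the compounds shown here, the exchange of 4-methylpiperidin-1-yl for isobutoxy gives a 3.0-fold higher number from compound 3 to compound 4 (0.48 log units; beyond the scatter), the first measured change at this aromatic carbon on a core carrying no other difference. The step lies beyond the scatter but is modest, so on this core the position accepts both a ring joined through nitrogen and an open chain joined through oxygen, with the read-out shifted only moderately and the ring-bearing amine giving the lower number. No available evidence accounts for the size or direction of this step.

This single exchange alters the ring, the linking atom and the heavy-atom count together, so the compounds shown do not separate the contribution of each. A cyclohexyloxy group would keep the ring and the oxygen link, a diethylamino group would keep the nitrogen link without a ring, and a piperidin-1-yl group lacking the methyl would test that carbon alone, leaving open which of these features goes with the lower number in this assay.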